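This account rests on a few compounds, and the source may have more. Where it says the series, first, only, none or still open, it means among the compounds named here.

Three compounds that share a central ring carrying three aromatic groups have been tested in a functional assay on DU-145 cells (Homo sapiens) for inhibition; a higher number here means a weaker inhibitor, a lower number a stronger inhibitor. Compound 1, with structure `Oc1ccccc1-c1cc(-c2cccc(F)c2)cc(-c2ccccc2O)n1`, gives only a limit in this assay: > 50000 nM. Compound 2, with structure `Oc1ccccc1-c1cc(-c2ccc(F)cc2)cc(-c2ccccc2O)n1`, likewise gives only a limit, > 50000 nM. The change from compound 1 to compound 2 is 4-fluorophenyl in place of 3-fluorophenyl on an aromatic carbon, and its step in this assay is a step that the two limits leave unreadable from compound 1 to compound 2, so its size cannot be read from these two values; the reason is that (the limit of > 50000 nM in this assay, at which 2 of the 3 values shown sit).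

Compound 3, with structure `Oc1ccc(-c2cc(-c3cccc(F)c3)cc(-c3cccc(O)c3)n2)cc1`, is the only one of the three to give a number: in this assay compound 3 gives 2700 nM. How the core of compound 3 differs from the core of compound 1 is not broken down here.

Compound 4, with structure `Oc1ccc(-c2cc(-c3ccc(F)cc3)cc(-c3cccc(O)c3)n2)cc1`, has not yet been measured. It differs from compound 3 by 4-fluorophenyl in place of 3-fluorophenyl on an aromatic carbon. This is the same kind of change as from compound 1 to compound 2, but the surroundings differ: in compound 1 the changing group sits meta to two 2-hydroxyphenyl groups, in compound 3 meta to a 3-hydroxyphenyl group and meta to a 4-hydroxyphenyl group. Since the earlier step is unreadable, the step from compound 3 to compound 4 is expected to be small, about a 1.1-fold higher number from compound 3 to compound 4 (0.05 log units; within the scatter), resting only on compound 3 with its value 2700 nM as the anchor. Compound 4 is therefore expected to give roughly 3000 nM, between 1000 nM and 9000 nM.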

Compound 4, half-maximal inhibitory concentration: 15200 nM
Compound 4: the middle estimate sits 5.1-fold (0.70 log units) below what was measured; the whole stated range lies below it.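

On the core of compound 3, 4-fluorophenyl in place of 3-fluorophenyl gives a 5.6-fold higher number from compound 3 to compound 4 (0.75 log units; beyond the scatter) in this assay, so on this core the change weakens inhibition by more than the usual scatter of repeat measurements. The same change on the core of compound 1 cannot be read, and no size can be set beside the new step, because neither compound in that pair gives a number: the limit of > 50000 nM in this assay, at which 2 of the 4 values shown sit. The series therefore offers only one readable case of this change, which shows that moving the fluorine can matter on one core but does not show whether the effect carries over from one core to another, since the pair on the other core neither supports nor contradicts it.

The compounds shown leave open whether the step would keep its direction and size on a core where the hydroxyphenyl groups are arranged in some further way, as a second readable pair would be needed to test that. They also leave open how the position of the fluorine would compare with a different group in its place, such as a chlorine, a methoxy group or an amine on the same phenyl ring.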